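Chloro for methyl: from compound 3 to compound 4

The source may hold more compounds than are shown below. What is called first, only, known or untested is meant among the compounds shown, and "the series" means these compounds.

Compound 3 `CCN1CCCC1CNC(=O)c1cc(NS(=O)(=O)NC)c(C)cc1OC` stands at the edge of a functional assay on the whole organism for inhibition, with Canis familiaris (Canis lupus familiaris) as the target; on this read-out lower numbers stand for an effect already at smaller amounts and higher numbers for an effect only at larger amounts of compound: compound 3 gives > 1 mg/kg, a limit rather than a number, as in the limit of > 1 mg/kg in this assay, at which 1 of the 3 values shown sits. Compound 1 `CCN1CCCC1CNC(=O)c1cc(NS(=O)(=O)N(C)C)c(Cl)cc1OC` gives 0.05 mg/kg in this assay, and compound 2 `CCN1CCCC1CNC(=O)c1cc(NS(C)(=O)=O)c(Cl)cc1OC` gives 0.1 mg/kg. Going by the values given here, the only measured step, a 2.0-fold higher number from compound 1 to compound 2 (0.30 log units; within the scatter), concerns the sulfonyl substituent and not the aromatic carbon at issue here. Compound 4 `CCN1CCCC1CNC(=O)c1cc(NS(=O)(=O)NC)c(Cl)cc1OC` arises from compound 3 by chloro in place of methyl on an aromatic carbon. Among the compounds with values here, no measured step covers this change; compound 1 and compound 2 both carry chloro and both sit far from the limit, so a large fall in number is expected, an at least 10-fold lower number from compound 3 to compound 4 (1.00 log units; beyond the scatter). For compound 4 the estimated value in this assay is 0.1 mg/kg, range 0.03 mg/kg to 0.5 mg/kg.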

Compound 4, dose for half-maximal effect: > 1 mg/kg
Compound 4: only a limit was reported; the forecaster's own chance of this, stated with the estimate: 15%; middle value at least 10-fold (1.00 log units) from the limit.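

Compound 4 gives > 1 mg/kg in this assay, a limit and not a number: the limit of > 1 mg/kg in this assay, at which 2 of the 4 values shown sit.

With chloro held on the aromatic carbon, the sulfonyl substituent alone separates the compounds: an at least 10-fold higher number from compound 2 to compound 4 (1.00 log units; beyond the scatter), and an at least 20-fold higher number from compound 1 to compound 4 (1.30 log units; beyond the scatter). The step between the two limits cannot be read, so chloro in place of methyl has no readable size here.

Open, going by these compounds, is whether any real difference between compound 3 and compound 4 lies past the limit. Also open, on these data alone, is how an ethylamino or unsubstituted amino group on the sulfonyl sulfur would read with chloro in place.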